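The source may hold more compounds than are shown below. What is called first, only, known or untested is meant among the compounds shown, and "the series" means these compounds.

Compound 1 `O=[N+]([O-])c1ccc(CN2CCC(n3cc(CC(OCc4cc(-c5ccccc5)no4)c4ccc(Br)cc4)nn3)CC2)cc1` and compound 2 `O=[N+]([O-])c1ccc(CN2CCC(n3cc(CC(OCc4cc(-c5cccc(Br)c5)no4)c4ccc(Br)cc4)nn3)CC2)cc1` share one core and differ only by a bromo in place of hydrogen on an aromatic carbon. In a functional assay on HCT-116 cells (Homo sapiens) for cytotoxicity, with a stated time of 48 h (a higher number here means a weaker inhibitor, a lower number a stronger inhibitor), compound 1 reaches only a limit of the assay, > 25000 nM. In this assay compound 2 likewise reaches only a limit, > 25000 nM. The step that the two limits leave unreadable from compound 1 to compound 2 is therefore not readable, and the series rests entirely on (the limit of > 25000 nM in this assay, at which 2 of the 2 values shown sit). Compound 3 `COc1ccccc1-c1cc(COC(Cc2cn(C3CCN(Cc4ccc([N+](=O)[O-])cc4)CC3)nn2)c2ccc(Br)cc2)on1` is not yet measured; it differs from compound 2 by 2-methoxyphenyl in place of 3-bromophenyl on an aromatic carbon. For the measured compounds named here, no measured step bears on this change. Compound 3 is expected to give about 30000 nM in this assay, between 12000 nM and 80000 nM, most likely again only a limit. The expected step that the limit leaves unreadable from compound 2 to compound 3 is accordingly no more than scatter.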

Compound 3, half-maximal inhibitory concentration: > 25000 nM
Compound 3 was reported as a limit; the forecaster's own chance of this, stated with the estimate: 75%; the middle value lies beyond the limit too.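

For the compounds shown here, compound 1, compound 2 and compound 3 all read only as limits in this assay, so no step among them can be read: the limit of > 25000 nM in this assay, at which 3 of the 3 values shown sit. The compounds shown leave open whether any change on the shared core gives a measurable value.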